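A few compounds are considered here, and "the series" means these few. Any claim that something is new, unique, unknown or untested is made for them only; others in the source may bear on it.

In a functional assay on HEK293 cells for positive allosteric modulation of metabotropic glutamate receptor 5 (Rattus norvegicus), read by fluorescence and calcium flux (on this read-out higher numbers stand for larger maximal responses and lower numbers for smaller maximal responses), three compounds that share one core have been measured. Compound 1 `C[C@@H](NC(=O)c1ccc(C#CC2CCCC2)cn1)C(C)(C)O` gives 63.7%. Compound 2 `Cc1cc(C#Cc2cccc(F)c2)cnc1C(=O)N[C@H](C)C(C)(C)O` gives 66.4%, and compound 3 `C[C@H](NC(=O)c1ccc(C#Cc2cccc(F)c2)cn1)C(C)(C)C` gives 70.8%. On these numbers compound 3 shows the largest of the three values, yet its gaps to compound 2 and to compound 1 both lie within the usual scatter of this kind of measurement, so the three cannot be separated with confidence. Compound 4 `CC(C)(O)CNC(=O)c1ccc(C#Cc2cccc(F)c2)cn1` has not yet been measured. It differs from compound 3 in one place: 2-hydroxy-2-methylpropyl in place of 1,2,2-trimethylpropyl on an amide-type nitrogen. Among the measured compounds shown here, no pair of the measured compounds differs in only one place, so no direct step is available to guide an expectation; what the measured set does show is that compounds 1 and 2 give values close to that of compound 3. Compound 4 is therefore expected to give a step of a number 7.8 percentage points lower from compound 3 to compound 4 (within the scatter), which is nothing beyond the scatter. The estimate for compound 4 in this assay is 63%, expected to fall between 48% and 78%.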

Compound 4, largest response reached (reported as efficacy), in percent of the reference or control that the assay uses: 61.5%
Compound 4: the middle estimate sits 1.5 percentage points above what was measured; low and high end bracket the measured number.
By their numbers in this assay, from the lowest: compounds 4, 1, 2 and 3 (each within the scatter of the next).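

In this assay, among the compounds shown here, the exchange of 1,2,2-trimethylpropyl for 2-hydroxy-2-methylpropyl on an amide-type nitrogen provides the first direct reading of a single change in this set, a step of a number 9.3 percentage points lower from compound 3 to compound 4 (within the scatter). The change removes a defined stereocentre and brings in a hydrogen-bond donor and a hydrogen-bond acceptor, yet this one step cannot separate the two compounds in maximal response. No measurement at hand offers an explanation for the size of this step. What the compounds shown leave open is whether an aminoalkyl or a carboxylic acid chain on the same nitrogen would give a step beyond the scatter from compound 3. From the compounds shown here alone, it also remains open how a longer chain ending in a methoxy group would read in this assay.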